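The compounds below may be only part of what the source reports. "The series", "measured", "known", "first", "only" and "open" are said of these compounds alone.

Measured so far in a functional assay on cells (Platelet, Homo sapiens) for inhibition; on this read-out higher numbers stand for weaker inhibition and lower numbers for stronger inhibition:
Compound 1 `CCOC(=O)c1ccc(-c2nn(-c3ccoc3)c3ccccc23)cc1`: > 10000 nM (a limit)
Compound 2 `O=C(O)c1ccc(-c2nn(Cc3ccccc3)c3ccccc23)cc1`: > 10000 nM (a limit)

Neither measured compound gives a number, and the record so far is the limit of > 10000 nM in this assay, at which 2 of the 2 values shown sit. Going by these compounds, compound 2 therefore stands at the limit of this assay, and how far its true value lies beyond that limit is unknown. Compound 3 `CNC(=O)c1ccc(-c2nn(Cc3ccccc3)c3ccccc23)cc1` differs from compound 2 in one place, with methylamino in place of hydroxy on a carbonyl carbon. The same change reads carboxy to methylcarbamoyl. Among the compounds with values here, no measured step shows what such a change does here, so the expectation is only a modest move towards stronger inhibition, and compound 3 may well remain at the limit. The expected step is an at least 1.2-fold lower number from compound 2 to compound 3 (0.09 log units; that floor lies within the scatter). For compound 3 the estimated value is 8000 nM, with an expected range from 2000 nM to 30000 nM.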

Compound 3, half-maximal inhibitory concentration: > 10000 nM
Compound 3: only a limit was reported; the forecaster's own chance of this, stated with the estimate: 60%; middle value at least 1.2-fold (0.09 log units) away from the limit.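

Compound 2 and compound 3 both give only a limit in this assay, so the step between them cannot be read, and the record remains: the limit of > 10000 nM in this assay, at which 3 of the 3 values shown sit.

The compounds shown leave open how far each true value lies beyond that limit, and whether any of them inhibits measurably in this assay.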